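Lengthening the chain on the shared core: from butyl to nonyl

The source may report more compounds than this note shows. Statements on the series, on what has been measured and on what is new or still open speak of the compounds shown alone.

The two measured compounds share one core and differ only in a chain on a saturated carbon. Compound 1 `CCC[C@]1(c2ccccc2)OC[C@H]([C@@H]2CCCCN2)O1` carries a propyl group, and in a functional assay (brain) for displacement of a labelled ligand, with Rattus norvegicus as the target (on this read-out lower numbers stand for stronger inhibition and higher numbers for weaker inhibition), compound 1 gives 69 nM. Compound 2 `CCCC[C@]1(c2ccccc2)OC[C@H]([C@@H]2CCCCN2)O1` carries a butyl group, and in this assay compound 2 gives 200 nM, the higher of the two numbers; the step of a 2.9-fold higher number from compound 1 to compound 2 (0.46 log units; beyond the scatter) is beyond the scatter. Compound 3 `CCCCCCCCC[C@]1(c2ccccc2)OC[C@H]([C@@H]2CCCCN2)O1` is not yet measured; it differs from compound 2 by pentyl in place of hydrogen on a saturated chain carbon, four bonds along the chain from a saturated ring carbon. Among the compounds with values here, the only step that bears on this change is the one from compound 1 to compound 2, where adding a single carbon weakened binding modestly. Adding five more carbons is expected to continue in the same direction, probably more strongly, so the step of a 7.5-fold higher number from compound 2 to compound 3 (0.88 log units; beyond the scatter) is expected as a further rise. Compound 3 is therefore estimated at 1500 nM, within a range from 400 nM to 6000 nM.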

Compound 3, inhibition constant: 43000 nM
Compound 3: the middle estimate sits 29-fold (1.46 log units) below what was measured; the measured number lies above the stated range.
By their numbers in this assay, from the lowest: compound 1; then compound 2; then compound 3.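

Lengthening this chain further does not simply continue the modest trend of a 2.9-fold higher number from compound 1 to compound 2 (0.46 log units; beyond the scatter): replacing butyl with nonyl gives a 220-fold higher number from compound 2 to compound 3 (2.33 log units; beyond the scatter), and the full change from propyl to nonyl gives a 620-fold higher number from compound 1 to compound 3 (2.79 log units; beyond the scatter). Across these three compounds in this assay, the number rises each time the chain grows, and none of them goes against this order, so a long chain at this position is far from neutral for inhibition here. Nothing available explains why the rise is so large.

Still open, as far as these compounds go, is whether the number climbs steadily through the pentyl, hexyl, heptyl and octyl chains or jumps sharply at one particular length. Also open, from the compounds shown here alone, is whether an ethyl or methyl chain would give a lower number than propyl, and how a branched chain such as isopropyl would behave.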